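Hydroxy to methoxy on the shared core

The compounds below may be only part of what the source reports. "The series", "measured", "known", "first", "only" and "open" are said of these compounds alone.

Measured in a functional assay on NUGC-3 cells (Homo sapiens) for antiproliferative activity, read by XTT assay; a higher number here means a weaker inhibitor, a lower number a stronger inhibitor:
Compound 1 `O=c1c(Cc2coc3cccc(OCC4CCCCC4)c3c2=O)coc2ccccc12`: 3530 nM
Compound 2 `CC(C)CCOc1cccc2occ(Cc3coc4ccccc4c3=O)c(=O)c12`: > 10000 nM (a limit)
Compound 3 `O=c1c(Cc2coc3cccc(O)c3c2=O)coc2ccccc12`: 3270 nM

Among the compounds with values here, compound 3, at 3270 nM, stands level with the only other true number in the set: a 1.1-fold lower number from compound 1 to compound 3 (0.03 log units; within the scatter). Compound 2 gives > 10000 nM, which is a limit of the assay. The step to compound 3 from that limit is an at least 3.0-fold lower number from compound 2 to compound 3 (0.48 log units; beyond the scatter).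

Compound 4 `COc1cccc2occ(Cc3coc4ccccc4c3=O)c(=O)c12` has methyl in place of hydrogen on an oxygen on an aromatic ring, hydroxy to methoxy (methyl in place of hydrogen on an oxygen on an aromatic ring). Both measured steps above change that same oxygen, and they disagree. Losing cyclohexylmethyl from compound 1 leaves the number within the scatter, while losing isopentyl from compound 2 goes beyond it. Read in reverse, they point to a small rise in this assay, possibly none beyond the scatter, with some chance of reaching the limit. Compound 4 is expected at about 5000 nM, within an estimated range of 2000 nM to 12000 nM. The estimated step is a 1.5-fold higher number from compound 3 to compound 4 (0.18 log units; within the scatter).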

Compound 4, half-maximal inhibitory concentration: 3190 nM
The estimate for compound 4 lay 1.6-fold (0.20 log units) above the measured number, and the stated range covers the measured number.
By their numbers in this assay, from the lowest: compounds 4, 3 and 1 (each within the scatter of the next). At a limit, above all of these: compound 2.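

In this assay methyl in place of hydrogen on this oxygen leaves the two compounds level (a 1.0-fold lower number from compound 3 to compound 4 (0.01 log units; within the scatter)), so the free hydroxy is not required for the number in this assay. Methoxy also stands level with the cyclohexylmethyl ether (a 1.1-fold lower number from compound 1 to compound 4 (0.04 log units; within the scatter)), which means hydrogen, methyl and cyclohexylmethyl on this oxygen cannot be told apart here. Isopentyl is the one group shown that goes against this (an at least 3.1-fold lower number from compound 2 to compound 4 (0.49 log units; beyond the scatter)), and compound 2 gives a limit, not a number: the limit of > 10000 nM in this assay, at which 1 of the 4 values shown sits.

On these data alone, with a single limit as the only exception, it stays open whether the isopentyl result reflects a general trend among ethers at this oxygen or is specific to that chain. A longer straight chain, or an amine or carboxylic acid carried on a chain at this oxygen, would extend the comparison.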